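Swapping a methylphenyl for a methylpyridinyl on the carbonyl

A few compounds are considered here, and "the series" means these few. Any claim that something is new, unique, unknown or untested is made for them only; others in the source may bear on it.

Of the compounds shown here, three sharing one core have been measured in an ADME assay on HEK-293T cells (Homo sapiens) for cytotoxicity, read by MTT assay, with a stated time of 24 h; a lower number here means that less compound is tolerated, a higher number that more compound is tolerated. Compound 1 `Cc1ccccc1C(=O)n1c(-c2cn(-c3ccccc3)nc2-c2ccc(F)cc2)nc2ccccc21` gives 189000 nM. Compound 2 `Cc1cccc(C(=O)n2c(-c3cn(-c4ccccc4)nc3-c3ccc(F)cc3)nc3ccccc32)c1` gives 148000 nM. Compound 3 `Cc1ccc(C(=O)n2c(-c3cn(-c4ccccc4)nc3-c3ccc(F)cc3)nc3ccccc32)cc1` gives 178000 nM. Among these three numbers compound 3 stands second highest, yet its neighbours sit very close: the step of a 1.1-fold lower number from compound 1 to compound 3 (0.03 log units; within the scatter) and the step of a 1.2-fold higher number from compound 2 to compound 3 (0.08 log units; within the scatter) both fall within the scatter, as does a 1.3-fold lower number from compound 1 to compound 2 (0.11 log units; within the scatter). Moving the methyl around the phenyl ring on the carbonyl carbon therefore made no visible difference in this assay.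

Compound 4 `Cc1ccc(C(=O)n2c(-c3cn(-c4ccccc4)nc3-c3ccc(F)cc3)nc3ccccc32)cn1` has not been measured. It differs from compound 3 by 6-methylpyridin-3-yl in place of 4-methylphenyl on a carbonyl carbon. Within the data shown here, no measured step swaps a ring carbon for a ring nitrogen; the three measured steps only move a methyl between positions on the same all-carbon ring, and each of them stayed within the scatter. Those steps bear on the new change only loosely, and with nothing pointing in either direction, compound 4 is expected to land near compound 3, giving an estimated step of a 1.0-fold lower number from compound 3 to compound 4 (0.02 log units; within the scatter) that stays within the scatter. The estimated value for compound 4 is 170000 nM, with a range from 85000 nM to 340000 nM.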

Compound 4, half-maximal cytotoxic concentration: 137000 nM
Estimate against measurement, compound 4: 1.2-fold (0.09 log units) above; the measured number falls inside the stated range.
By their numbers in this assay, from the lowest: compounds 4, 2, 3 and 1 (each within the scatter of the next).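

In this assay, changing the ring on the carbonyl carbon from 4-methylphenyl to 6-methylpyridin-3-yl swaps one ring carbon for a ring nitrogen and adds a hydrogen-bond acceptor, yet the result is only a small step (a 1.3-fold lower number from compound 3 to compound 4 (0.11 log units; within the scatter)), and the comparisons with the other two methylphenyl compounds (a 1.1-fold lower number from compound 2 to compound 4 (0.03 log units; within the scatter); a 1.4-fold lower number from compound 1 to compound 4 (0.14 log units; within the scatter)) also stay within the scatter. The earlier compounds shown here only showed a methyl moving around an all-carbon ring, whereas these results show that a change to the ring atoms themselves also leaves the tolerated concentration without a clear shift. Nothing available explains why this number stays so close to the others.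

On these data alone, all four compounds still carry a methyl-bearing six-membered aromatic ring on the carbonyl carbon, so it remains open whether that ring would stay this close with an amine or a carboxylic acid attached, or with a longer alkyl chain in place of the methyl. As far as these compounds go, it is also open whether a ring with no methyl at all, or one with a second ring nitrogen, would fall within the scatter of these four.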